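A few compounds are considered here, and "the series" means these few. Any claim that something is new, unique, unknown or untested is made for them only; others in the source may bear on it.

Compound 1 `N#Cc1ccc(NC(=O)c2ccc(Cl)cc2O)cc1`: 1920 nM
Compound 2 `N#Cc1ccc2nc(-c3ccccc3O)[nH]c2c1`: > 10000 nM (a limit)
Compound 3 `O=C(Nc1ccc(OC(F)(F)F)c(Cl)c1)c1ccc(C(F)(F)F)cc1O`: 640 nM

The three compounds were tested in a functional assay on KG-1 cells (Homo sapiens) for cytotoxicity, read by luminescence and CellTiter-Glo, with a stated time of 3 days; a higher number here means a weaker inhibitor, a lower number a stronger inhibitor. Compound 1 gives 1920 nM, the higher of the two exact numbers. Compound 3 gives 640 nM, and the gap between these two values lies beyond the scatter. Compound 2 returned only a limit of the assay, > 10000 nM, so it has no exact number to set beside the others. Compounds 1 and 3 differ in more than one place, so their values isolate no single change.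

The next compound is compound 4 `N#Cc1ccc(NC(=O)c2ccc(-c3cccnc3)cc2O)cc1`, which departs from compound 1 at a single site: pyridin-3-yl in place of chloro on an aromatic carbon. In words, pyridin-3-yl stands in place of chloro on an aromatic carbon, meta to a hydroxy group and para to a large group. Among the compounds with values here, no measured pair shows a change at this site, so the expectation is a cautious one. In this assay, a modest move to a higher number is expected, of a size not far beyond the scatter. The estimated change is a 1.5-fold higher number from compound 1 to compound 4 (0.16 log units; within the scatter). Compound 4 is expected at 2800 nM, with an estimated range from 800 nM to 9500 nM.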

Compound 4, half-maximal inhibitory concentration: 7940 nM
For compound 4 the middle estimate is 2.8-fold (0.45 log units) below the measured one, and the stated range covers the measured number.
By their numbers in this assay, from the lowest: compound 3; then compound 1; then compound 4. At a limit, above all of these: compound 2.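

Within the data shown here, compound 4 gives the first reading at this position, on an aromatic carbon meta to a hydroxy group and para to a large group. In this assay, pyridin-3-yl in place of chloro gives a 4.1-fold higher number from compound 1 to compound 4 (0.62 log units; beyond the scatter), so the change counts against activity here and its size stands clear of the usual scatter. This is only one step, and it leaves little room to read further losses at this site as exact numbers, since the assay has a ceiling that one compound has already reached: the limit of > 10000 nM in this assay, at which 1 of the 4 values shown sits.

The ring and its nitrogen enter together in this step, so the compounds shown leave open whether a plain phenyl group would give a similar number or whether the nitrogen itself matters. They also leave open whether a small group such as fluoro or methyl at this position would stay close to compound 1, and whether an amine on the pyridine ring, or the pyridin-4-yl isomer, would move the number in either direction.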